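Dropping a Methyl on a Shared Core: Compound 4 Expected

This account rests on a few compounds, and the source may have more. Where it says the series, first, only, none or still open, it means among the compounds named here.

Compound 1 `N/C(=N\NC(=S)N1CCCCC1)c1ccccn1`: 6900 nM
Compound 2 `Cc1cccc(/C(N)=N/NC(=S)N2CCCCC2)n1`: 12400 nM
Compound 3 `Cc1cccc(/C(N)=N/NC(=S)N2CCCC2)n1`: 4000 nM

Three compounds were tested in a functional assay on A-431 cells (Homo sapiens) for cytotoxicity, read by MTT assay, with a stated time of 72 h; a lower number here means a stronger inhibitor, a higher number a weaker inhibitor. Compound 2 gives 12400 nM, and compound 1 gives 6900 nM; the change between them is hydrogen in place of methyl on an aromatic carbon, a step of a 1.8-fold lower number from compound 2 to compound 1 (0.25 log units; within the scatter). Compound 3 differs from compound 2 at the thiocarbonyl carbon, (pyrrolidin-1-yl in place of piperidin-1-yl on a thiocarbonyl carbon), which made a step of a 3.1-fold lower number from compound 2 to compound 3 (0.49 log units; beyond the scatter). Compound 3 gives 4000 nM, and its gap to compound 1 is within the scatter.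

Compound 4 `N/C(=N\NC(=S)N1CCCC1)c1ccccn1` has not yet been measured. It differs from compound 3 by hydrogen in place of methyl on an aromatic carbon. For the measured compounds named here, this is the same change as the one from compound 2 to compound 1, made at the same place; only the cores differ, in the way described between compound 2 and compound 3. A step of similar size is expected from compound 3 to compound 4 in this assay, namely a 1.6-fold lower number from compound 3 to compound 4 (0.20 log units; within the scatter), because a 1.8-fold lower number from compound 2 to compound 1 (0.25 log units; within the scatter) stayed within the scatter. Compound 4 is therefore estimated at 2500 nM, expected to fall between 1000 nM and 6000 nM.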

Compound 4, half-maximal inhibitory concentration: 1700 nM
The estimate for compound 4 lay 1.5-fold (0.17 log units) above the measured number; the range from low to high includes it.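

In this assay, hydrogen in place of methyl on the aromatic carbon gave a 2.4-fold lower number from compound 3 to compound 4 (0.37 log units; beyond the scatter), which closely matches the step seen with the same change on the other core: the same change on two cores in this assay, a 1.8-fold lower number (0.25 log units; within the scatter) from compound 2 to compound 1 and a 2.4-fold lower number (0.37 log units; beyond the scatter) from compound 3 to compound 4, 1.3-fold (0.12 log units) apart, within the scatter of two such steps. The exchange of piperidin-1-yl for pyrrolidin-1-yl on the thiocarbonyl carbon also carried over, giving a 4.1-fold lower number from compound 1 to compound 4 (0.61 log units; beyond the scatter) on the core without the methyl, again in line with its earlier step: the same change on two cores in this assay, a 3.1-fold lower number (0.49 log units; beyond the scatter) from compound 2 to compound 3 and a 4.1-fold lower number (0.61 log units; beyond the scatter) from compound 1 to compound 4, 1.3-fold (0.12 log units) apart, within the scatter of two such steps. Across these four compounds, each change therefore kept its size from one core to the other, but this rests on a single pair of cores and a single assay, so it does not show that the changes would transfer more widely or why they lower the number.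

The compounds shown leave open how a chlorine or a methoxy group on that aromatic carbon would behave, or a morpholin-4-yl group on the thiocarbonyl carbon. They also leave open whether the same steps would appear in any other assay.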